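The source may hold more compounds than are shown below. What is called first, only, known or untested is meant among the compounds shown, and "the series" means these compounds.

Compound 1 `COc1ccc(OC)c(/C=N/NC(=O)Nc2ccc(Oc3ccnc(-c4nncn4CCN(C)C)c3)c(F)c2)c1` — 2930 nM in a functional assay on NCI-H460 cells (Homo sapiens) for cytotoxicity, read by MTT assay, with a stated time of 72 h; a higher number here means a weaker inhibitor, a lower number a stronger inhibitor.
Compound 2 `CN(C)CCn1cnnc1-c1cc(Oc2ccc(NC(=O)N/N=C/c3ccccc3O[N+](=O)[O-])cc2F)ccn1` — 1270 nM.
Compound 3 `CN(C)CCn1cnnc1-c1cc(Oc2ccc(NC(=O)N/N=C/c3ccc(O)c(O)c3)cc2F)ccn1` — 1930 nM.

Compound 3 holds the second highest of the three numbers; its gaps to compound 1 and to compound 2 are both within the scatter, as a 1.5-fold higher number from compound 2 to compound 3 (0.18 log units; within the scatter) shows. Only a 2.3-fold lower number from compound 1 to compound 2 (0.36 log units; beyond the scatter) lies beyond the scatter, and that step is modest. Compound 4 `CN(C)CCn1cnnc1-c1cc(Oc2ccc(NC(=O)N/N=C/c3ccc(O)c(F)c3)cc2F)ccn1` has not been measured; it differs from compound 3 by fluoro in place of hydroxy on an aromatic carbon. Every measured step alters the aryl group on the carbon with a double bond to nitrogen, and a 1.5-fold lower number from compound 1 to compound 3 (0.18 log units; within the scatter) shows such a swap moving the number little. The same is expected here, so a 1.0-fold lower number from compound 3 to compound 4 (0.01 log units; within the scatter) is the expected step, not beyond the scatter. Compound 4 is therefore estimated at 1900 nM, with a range of 900 nM to 4000 nM.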

Compound 4, half-maximal inhibitory concentration: 2620 nM
Compound 4: middle estimate off by 1.4-fold (0.14 log units), on the low side, and the stated range covers the measured number.
By their numbers in this assay, from the lowest: compounds 2, 3, 4 and 1 (each within the scatter of the next, the first and the last beyond it).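

Fluoro in place of hydroxy, ortho to a hydroxy group, is the first change within the aryl group rather than a swap of the whole group, and a 1.4-fold higher number from compound 3 to compound 4 (0.13 log units; within the scatter) shows that 3-fluoro-4-hydroxyphenyl is not resolved from 3,4-dihydroxyphenyl. The new group is also level with 2,5-dimethoxyphenyl, a 1.1-fold lower number from compound 1 to compound 4 (0.05 log units; within the scatter), while a 2.1-fold higher number from compound 2 to compound 4 (0.31 log units; beyond the scatter) is a modest step, so 2-(nitrooxy)phenyl now stands apart from two aryl groups, though not from 3,4-dihydroxyphenyl. No supporting data bear on why these steps are this size.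

Open, on these data alone, is whether an amine, a carboxylic acid or a methoxy group on this carbon would give a step beyond the scatter. Also open, as far as these compounds go, is whether the fluoro result holds without the remaining hydroxy.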